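The source may hold more compounds than are shown below. What is called first, only, known or untested is meant among the compounds shown, and "the series" means these compounds.

In a functional assay on CCRF-CEM cells (Homo sapiens) for antiproliferative activity, with a stated time of 72 h (a lower number here means a stronger inhibitor, a higher number a weaker inhibitor), compound 1 `OC[C@H]1O[C@@H](n2cnc3c(NCc4ccc(Br)cc4)ncnc32)[C@H](O)[C@@H]1O` gives 20600 nM, compound 2 `OC[C@H]1O[C@@H](n2cnc3c(NCc4ccc(Cl)c(Cl)c4)ncnc32)[C@H](O)[C@@H]1O` gives 3800 nM and compound 3 `OC[C@H]1O[C@@H](n2cnc3c(NCc4ccc(F)cc4F)ncnc32)[C@H](O)[C@@H]1O` gives 7100 nM. Compound 3 stands clear of the 4-bromophenyl compound, as a 2.9-fold lower number from compound 1 to compound 3 (0.46 log units; beyond the scatter) shows, and a 5.4-fold lower number from compound 1 to compound 2 (0.73 log units; beyond the scatter) is a modest step of the same kind. Compound 4 `OC[C@H]1O[C@@H](n2cnc3c(NCc4ccc(F)c(Cl)c4)ncnc32)[C@H](O)[C@@H]1O`, not yet measured, carries 3-chloro-4-fluorophenyl in place of 2,4-difluorophenyl on a saturated chain carbon bound to a nitrogen on an aromatic ring. The nearest guide is a 1.9-fold higher number from compound 2 to compound 3 (0.27 log units; within the scatter), since the new group resembles the 3,4-dichlorophenyl group of compound 2. No change beyond the scatter is therefore expected in this assay, and the estimated step is a 1.4-fold lower number from compound 3 to compound 4 (0.15 log units; within the scatter). For compound 4 the expected value is 5000 nM, with an estimated range of 2200 nM to 11500 nM.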

Compound 4, half-maximal inhibitory concentration: 3400 nM
Beside the measured number, compound 4's estimate is 1.5-fold (0.17 log units) above it; the measured number falls inside the stated range.
By their numbers in this assay, from the lowest: compounds 4, 2 and 3 (each within the scatter of the next, the first and the last beyond it); then compound 1.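

In this assay, 3-chloro-4-fluorophenyl on this saturated chain carbon separates from 2,4-difluorophenyl by more than the scatter (a 2.1-fold lower number from compound 3 to compound 4 (0.32 log units; beyond the scatter)), whereas the step from compound 2 to compound 3 stayed within it. Fluoro in place of one chloro on an aromatic carbon leaves the number within the scatter (a 1.1-fold lower number from compound 2 to compound 4 (0.05 log units; within the scatter)), and the clear margin over the 4-bromophenyl group holds (a 6.1-fold lower number from compound 1 to compound 4 (0.78 log units; beyond the scatter)). Nothing given here explains these differences. Still open, from the compounds shown here alone, is whether a methoxy group on the ring, a pyridine ring or a longer chain in place of the benzyl would keep these numbers.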